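This account rests on a few compounds, and the source may have more. Where it says the series, first, only, none or still open, it means among the compounds named here.

Measured in an ADME assay on T29 cells (Homo sapiens) for cytotoxicity, read by sulforhodamine B assay, with a stated time of 3 days; on this read-out higher numbers stand for weaker inhibition and lower numbers for stronger inhibition:

- Compound 1 `O=Cc1cn(CCCOc2ccc(Cl)cc2)c2ccccc12` gives > 31600 nM
- Compound 2 `O=Cc1cn(Cc2ccc(Cl)cc2)c2ccc(F)cc12` gives > 31600 nM
- Compound 3 `OCc1cn(Cc2cccc(F)c2)c2ccccc12` gives > 31600 nM

Each of these entries is a limit of the assay and not a number, and together they show (the limit of > 31600 nM in this assay, at which 3 of the 3 values shown sit). Among the compounds with values here, no two of the measured compounds differ in one place only, so no measured step is available as a guide.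

Compound 3 gives > 31600 nM, which is a limit. It therefore offers a boundary rather than a number to start from.

Compound 4 `OCc1cn(Cc2cccc(C(F)(F)F)c2)c2ccccc12` has trifluoromethyl in place of fluoro on an aromatic carbon, meta to a large group (trifluoromethyl in place of fluoro on an aromatic carbon). With every measured compound at the same limit, no step beyond the scatter is expected in this assay, in either direction. The estimated change is a number no higher from compound 3 to compound 4 (the limit leaves the size open). Compound 4 is estimated at 31600 nM, with an expected range from 15000 nM to 50000 nM, and the assay is expected to report it most probably as a limit only.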

Compound 4, half-maximal inhibitory concentration: > 31600 nM
Compound 4 was reported as a limit; the forecaster's own chance of this, stated with the estimate: 85%; the middle value sits exactly at the limit.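

Compound 3 and compound 4 are both reported as limits in this assay, so trifluoromethyl in place of fluoro gives no readable step. The compounds shown leave open whether any change in structure would give a number rather than a limit: the limit of > 31600 nM in this assay, at which 4 of the 4 values shown sit.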